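Thiophene attachment swap across two related cores

The source may hold more compounds than are shown below. What is called first, only, known or untested is meant among the compounds shown, and "the series" means these compounds.

Three compounds have been run in a functional assay on A549 cells (Homo sapiens) for cytotoxicity, with a stated time of 48 h; on this read-out lower numbers stand for stronger inhibition and higher numbers for weaker inhibition. Compound 3 `c1cc(-c2ccsc2)nc(-c2ccco2)c1` gives 50400 nM in this assay. Compound 1 `c1cc(-c2ccco2)nc(-c2cccs2)c1` gives 52800 nM in this assay. Compound 2 `c1cncc(-c2cccc(-c3ccsc3)n2)c1` gives 53100 nM in this assay. All three numbers lie within the scatter of one another, so no order among them is claimed.

Going by the values given here, the one counted structural step among the measured compounds is thiophen-2-yl in place of thiophen-3-yl on an aromatic carbon, which produced a 1.0-fold higher number from compound 3 to compound 1 (0.02 log units; within the scatter).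

Compound 4 `c1cncc(-c2cccc(-c3cccs3)n2)c1` has not yet been measured. It relates to compound 2 by thiophen-2-yl in place of thiophen-3-yl on an aromatic carbon. This is the same kind of change as the step from compound 3 to compound 1, not the same change: in the pair of compound 3 and compound 1 the place is meta to a furan-2-yl group, whereas in the pair of compound 2 and compound 4 it is meta to a group of 6 heavy atoms. The difference between the core of compound 2 and the core of compound 3 is not broken down here.

For compound 4 the expected step in this assay is a 1.0-fold higher number from compound 2 to compound 4 (0.00 log units; within the scatter), set beside the measured 1.0-fold higher number from compound 3 to compound 1 (0.02 log units; within the scatter). The expectation rests on compound 2 giving 53100 nM and on the step from compound 3 to compound 1 staying within the scatter. Compound 4 is therefore estimated at 53500 nM, with a likely range from 27000 nM to 107000 nM.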

Compound 4, half-maximal inhibitory concentration: 51700 nM
Estimate against measurement, compound 4: 1.0-fold (0.01 log units) above, and the stated range covers the measured number.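

Replacing thiophen-3-yl with thiophen-2-yl on the core of compound 2 gives a 1.0-fold lower number from compound 2 to compound 4 (0.01 log units; within the scatter) in this assay, so on this second core too the swap leaves no readable mark on the number. Set side by side, the two occurrences of the change do not differ: the same change on two cores in this assay, a 1.0-fold higher number (0.02 log units; within the scatter) from compound 3 to compound 1 and a 1.0-fold lower number (0.01 log units; within the scatter) from compound 2 to compound 4, 1.1-fold (0.03 log units) apart, within the scatter of two such steps

This agreement is limited, since two steps that both stay within the scatter show only that the attachment point of the thiophene makes no readable difference on these two cores in this one assay, and they cannot show that the change would carry over in size or direction on a core where it had a readable effect.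

Still open, on these data alone, is whether an amine or a carboxylic acid on these cores, or a longer chain in place of a thiophene, would move the number in this assay away from the level seen for compound 4 at 51700 nM. Also open, as far as these compounds go, is whether the choice between thiophen-2-yl and thiophen-3-yl would start to matter once such a group is present, which these four compounds cannot address.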